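The compounds below may be only part of what the source reports. "The series", "measured", "known", "first", "only" and "open" are said of these compounds alone.

Working notes on the series. Compound 1 `O[C@@H]1[C@@H](O)CN[C@H]1c1ccc(-c2ccccc2)cc1` gives 15.6% in an assay on lysosomes for inhibition of Maltase-glucoamylase (Homo sapiens), read by spectrophotometry, tested at 1000 uM; on this read-out higher numbers stand for more inhibition at the one concentration tested (going by the name of the read-out) and lower numbers for less inhibition. Compound 2 `Cc1ccc([C@@H]2NC[C@H](O)[C@H]2O)cc1` gives 4.8% in this assay, the step being a number 10.8 percentage points lower from compound 1 to compound 2 (beyond the scatter). Compound 3 `Cc1ccc([C@H]2NC[C@@H](O)[C@@H]2O)cc1` gives 15% in this assay; the step of a number 10.2 percentage points higher from compound 2 to compound 3 (beyond the scatter) goes with the fact that compounds 2 and 3 differ only in the configuration as drawn. On these numbers compound 3 stands second highest of the three, with compound 1 within the scatter of it and compound 2 beyond it. Compound 4 `O[C@H]1[C@H](O)CN[C@@H]1c1ccc(-c2ccccc2)cc1` differs from compound 3 as follows: phenyl in place of methyl on an aromatic carbon. Among the measured compounds shown here, the single measured step that bears on this change is a number 10.8 percentage points lower from compound 1 to compound 2 (beyond the scatter), run in the opposite direction; reversing it suggests a modest rise. Compound 4 is therefore expected at 25%, range 12% to 40%, an expected step of a number 10 percentage points higher from compound 3 to compound 4 (within the scatter) in this assay.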

Compound 4, a percentage reported as inhibition, at one concentration (the size of the read-out at that concentration, not a potency): 2.9%
The estimate for compound 4 lay 22.1 percentage points above the measured number; measured number outside the range, below it.
By their numbers in this assay, from the lowest: compounds 4 and 2 (each within the scatter of the next); then compounds 3 and 1 (each within the scatter of the next).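

Phenyl in place of methyl on this aromatic carbon has no single direction in this assay: a number 12.1 percentage points lower from compound 3 to compound 4 (beyond the scatter), so the outcome of the change depends on the configuration of the core: the same change on two cores in this assay, a number 10.8 percentage points lower (beyond the scatter) from compound 1 to compound 2 and a number 12.1 percentage points higher (beyond the scatter) from compound 4 to compound 3, 22.9 percentage points apart, beyond the scatter of two such steps With phenyl in place, inverting all stereocentres gives a number 12.7 percentage points lower from compound 1 to compound 4 (beyond the scatter), the opposite direction to the step seen with methyl: the fact that compounds 1 and 4 differ only in the configuration as drawn Which of the three stereocentres carries this reversal stays open, since each pair inverts all of them together. Also open, as far as these compounds go, is how groups such as a carboxylic acid or an amine on this aromatic carbon would behave on either core.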